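Aryl amine replacing cyclohexylamine on a shared core

The source may report more compounds than this note shows. Statements on the series, on what has been measured and on what is new or still open speak of the compounds shown alone.

Measured compounds:
- compound 1, `O=C1C=C(NC2CCCCC2)C(=O)c2c1nc1n2[C@H]2OC[C@@H](O)[C@H]2OC1`: > 8000 nM
- compound 2, `O=C1C(N2CCCC2)=CC(=O)c2c1nc1n2[C@H]2OC[C@@H](O)[C@H]2OC1`: > 16000 nM

In a functional assay on MCF7 cells (Homo sapiens) for inhibition, read by sulforhodamine B assay (on this read-out higher numbers stand for weaker inhibition and lower numbers for stronger inhibition), compound 1 gives > 8000 nM, which is a limit of the assay rather than a number. Compound 2 likewise reaches only a limit, > 16000 nM. Both values shown are therefore limits, so compound 1 has no measured position among them. Compound 3, `Cc1ccc(NC2=CC(=O)c3nc4n(c3C2=O)[C@H]2OC[C@@H](O)[C@H]2OC4)cc1`, carries 4-methylphenyl in place of cyclohexyl on an amine nitrogen. For the measured compounds named here, with no measured step of this kind, the expected change is none beyond the scatter, and the estimated step that the limit leaves unreadable from compound 1 to compound 3 is small. Compound 3 is expected to give about 10000 nM, within 3000 nM to 30000 nM.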

Compound 3, half-maximal inhibitory concentration: 1660 nM
Compound 3: middle estimate off by 6.0-fold (0.78 log units), on the high side, outside the stated range (below it).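

In this assay, the group on the amine nitrogen matters: 4-methylphenyl in place of cyclohexyl gives an at least 4.8-fold lower number from compound 1 to compound 3 (0.68 log units; beyond the scatter). Compound 3 is the only compound shown with a measured number rather than a limit, so this change brings inhibition into the range the assay can read. The true size of the step stays open because compound 1 stands at a limit: the limit of > 8000 nM in this assay, at which 1 of the 3 values shown sits.

As far as these compounds go, whether the methyl group contributes, or the aromatic ring alone is enough, remains open. Plain phenyl on the same nitrogen would separate the two.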